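Swapping an amino link for an ether at mGlu2

The compounds below may be only part of what the source reports. "The series", "measured", "known", "first", "only" and "open" are said of these compounds alone.

Measured so far:
- compound 1 `N#Cc1c(-c2ccc(NC3CCOCC3)c(Cl)c2)ccn2c(CC(F)(F)F)cnc12`: 307%
- compound 2 `O[C@H]1CC[C@H](n2ccc3cc(-c4ccn5c(CC(F)(F)F)cnc5c4Cl)ccc32)CC1`: 244%

In a functional assay on CHO cells for agonist activity at metabotropic glutamate receptor 2 (Homo sapiens) (on this read-out lower numbers stand for smaller maximal responses and higher numbers for larger maximal responses), compound 1 gives 307%, the higher of the two numbers; compound 2 sits a gap below it that lies beyond the usual scatter. Compound 3 `N#Cc1c(-c2ccc(OC3CCOCC3)c(Cl)c2)ccn2c(CC(F)(F)F)cnc12` has not been measured. It differs from compound 1 in one place ((oxan-4-yl)oxy in place of (oxan-4-yl)amino on an aromatic carbon), keeping the chloro group and the shared core. For the measured compounds named here, no measured pair shows this kind of swap, so its effect is uncertain; a modest drop or no change beyond the scatter seems most likely. Compound 3 is expected to reach about 265%, between 180% and 350%, a step of a number 42 percentage points lower from compound 1 to compound 3 (beyond the scatter).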

Compound 3, largest response reached (Emax), in percent of the reference or control that the assay uses: 173%
Estimate against measurement, compound 3: 92 percentage points above; the whole stated range lies above it.
By their numbers in this assay, from the lowest: compound 3; then compound 2; then compound 1.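

For the compounds shown here, this is the first one-place comparison in the set, and it shows that the single atom linking the oxane ring to the aromatic ring matters: in this assay, putting (oxan-4-yl)oxy in place of (oxan-4-yl)amino gives a number 134 percentage points lower from compound 1 to compound 3 (beyond the scatter). The two groups have the same ring and the same number of heavy atoms, but only the amino group has a hydrogen-bond donor. Nothing measured here explains the fall in response. On these data alone, it remains open whether that donor or the nitrogen itself matters, which a methylamino or methylene link could help separate. As far as these compounds go, whether other cores respond to this swap in the same way is also open.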